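Swapping a methyl for a chlorine on the pyridine

The source may report more compounds than this note shows. Statements on the series, on what has been measured and on what is new or still open speak of the compounds shown alone.

Of the compounds shown here, three sharing one core have been measured in an assay on HEK293 cells for inhibition of kynurenine 3-monooxygenase (Homo sapiens), read by LC-MS, with a stated time of 20 h; a lower number here means a stronger inhibitor, a higher number a weaker inhibitor. Going by the values given here, compound 1 `O=C(O)CCn1c(=O)oc2cc(OCc3ccccc3)c(Cl)cc21` gives 1580 nM, compound 3 `O=C(O)CCn1c(=O)oc2cc(OCc3ccccn3)c(Cl)cc21` gives 5010 nM, and the step of a 3.2-fold higher number from compound 1 to compound 3 (0.50 log units; beyond the scatter) is the only single-point change among them. Compound 2 `Cc1ccnc([C@@H](C)Oc2cc3oc(=O)n(CCC(=O)O)c3cc2Cl)c1` gives 31600 nM and stands highest of the three numbers, beyond the scatter from both others; compared with compound 3 its number is higher, and it sits furthest from compound 1.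

Compound 4 `C[C@@H](Oc1cc2oc(=O)n(CCC(=O)O)c2cc1Cl)c1ccc(Cl)cn1` differs from compound 2 in one place: 5-chloropyridin-2-yl in place of 4-methylpyridin-2-yl on a saturated chain carbon bound to an oxygen on an aromatic ring and a saturated chain carbon. Among the compounds with values here, no measured pair bears on this exchange directly; the one known step concerns a different ring change and offers no guide to the size or direction here. The expectation therefore rests mainly on compound 2 itself, and the step of a 1.6-fold lower number from compound 2 to compound 4 (0.20 log units; within the scatter) is estimated to stay close to the scatter. Compound 4 is expected to give about 20000 nM in this assay, within a range of 6300 nM to 63000 nM.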

Compound 4, half-maximal inhibitory concentration: 100 nM
Estimate against measurement, compound 4: 200-fold (2.30 log units) above; the whole stated range lies above it.
By their numbers in this assay, from the lowest: compound 4; then compound 1; then compound 3; then compound 2.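

The exchange of 4-methylpyridin-2-yl for 5-chloropyridin-2-yl on this saturated chain carbon gives a 320-fold lower number from compound 2 to compound 4 (2.50 log units; beyond the scatter) in this assay, although the groups leaving and entering have the same count of heavy atoms, hydrogen-bond donors and hydrogen-bond acceptors. Going by these compounds alone, the one earlier step, a 3.2-fold higher number from compound 1 to compound 3 (0.50 log units; beyond the scatter) for pyridin-2-yl in place of phenyl, gave no sign that a change to this ring could carry so much weight. Nothing measured here accounts for the size of the new step.

The exchange alters both the substituent and where it stands on the pyridine, so these two compounds cannot separate the effect of the chlorine from that of its place. Going by these compounds, how a fluorine or a nitrile would fare on the pyridine also remains open, as does the effect of the chain methyl alongside the 5-chloropyridin-2-yl group.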